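Amino in place of methyl: a small step expected

The source may hold more compounds than are shown below. What is called first, only, known or untested is meant among the compounds shown, and "the series" means these compounds.

In a functional assay on GTL 16 cells (Homo sapiens) for cytotoxicity, with a stated time of 72 h (on this read-out lower numbers stand for an effect already at smaller amounts and higher numbers for an effect only at larger amounts of compound), compound 1 `Cc1nc(N)nc2c1C(=O)N[C@@H](c1ccc(F)cc1-c1cccc(O)n1)C2` gives > 10000 nM, a limit of the assay and not a number. Compound 2 `COc1cncc(-c2cc(F)ccc2[C@H]2Cc3nc(N)nc(C)c3C(=O)N2)n1` gives 14 nM, and compound 3 `COc1nc(-c2cc(F)ccc2[C@H]2Cc3nc(N)nc(C)c3C(=O)N2)cnc1C` gives 34 nM. Compound 3 therefore holds the higher of the two true numbers, and compound 2 is its nearest neighbour. The next compound, compound 4 `COc1nc(-c2cc(F)ccc2[C@H]2Cc3nc(N)nc(C)c3C(=O)N2)cnc1N`, keeps everything in compound 3 except one group, with amino in place of methyl on an aromatic carbon. Its value in this assay is not yet known.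

Two measured steps are large, an at least 710-fold lower number from compound 1 to compound 2 (2.85 log units; beyond the scatter) and an at least 290-fold lower number from compound 1 to compound 3 (2.46 log units; beyond the scatter), but each exchanges a whole aromatic group, so they offer little guidance for a single-group change. The closest guide is the modest step of a 2.4-fold higher number from compound 2 to compound 3 (0.39 log units; beyond the scatter), which is methyl in place of hydrogen on an aromatic carbon. Within the data shown here, no amino group has yet been measured on this ring, so the guide is only partial. A modest move to a lower number is expected, though the shift may not exceed the scatter. The estimated step is a 1.7-fold lower number from compound 3 to compound 4 (0.23 log units; within the scatter). For compound 4 the expected value is 20 nM, with an estimated range from 6 nM to 70 nM.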

Compound 4, half-maximal effective concentration: 34 nM
Compound 4: middle estimate off by 1.7-fold (0.23 log units), on the low side; low and high end bracket the measured number.
By their numbers in this assay, from the lowest: compound 2; then compounds 3 and 4 (each within the scatter of the next). At a limit, above all of these: compound 1.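

Methyl and amino cannot be told apart at this position in this assay: on an aromatic carbon next to the ring nitrogen and ortho to a methoxy group, the change gives no change at the digits printed from compound 3 to compound 4 (within the scatter), even though the amino group brings a hydrogen-bond donor and a hydrogen-bond acceptor that methyl lacks. Measured against hydrogen, amino gives a 2.4-fold higher number from compound 2 to compound 4 (0.39 log units; beyond the scatter), a step of the same size as the one printed for methyl, a 2.4-fold higher number from compound 2 to compound 3 (0.39 log units; beyond the scatter), so in these three compounds the two groups sit level with each other and modestly above the compound with hydrogen here. The large step of an at least 290-fold lower number from compound 1 to compound 4 (2.46 log units; beyond the scatter) exchanges a whole aromatic group and starts from a limit of the assay, not a number: the limit of > 10000 nM in this assay, at which 1 of the 4 values shown sits.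

Going by these compounds, with only hydrogen, methyl and amino compared at this position, it remains open whether a longer chain such as ethyl, or a larger group such as dimethylamino, would stay level with these or move the number further. On these data alone, it is equally open whether an ethoxy group in place of the neighbouring methoxy group would change the number in this assay.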